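Replacing methoxy with (cyclopropylmethyl)amino on compound 2

This account rests on a few compounds, and the source may have more. Where it says the series, first, only, none or still open, it means among the compounds named here.

Compound 1 `Nc1nc(C(F)(F)F)cc2c1[nH]c(=O)n2Cc1ccc(C(F)(F)F)nc1`: < 8.5 mL.min-1.g-1
Compound 2 `COc1ccc(Cn2c(=O)[nH]c3c(N)nc(C(F)(F)F)cc32)cn1`: < 9 mL.min-1.g-1

Both entries are limits of an in vitro ADME assay on microsomes from liver (Rattus norvegicus) for metabolic stability (a higher number here means faster removal of the compound, a lower number slower removal), not numbers. Compound 2 has no exact value here, only its limit of < 9 mL.min-1.g-1. Compound 1 likewise stands only at its limit of < 8.5 mL.min-1.g-1.

For the measured compounds named here, the one measured change at this aromatic carbon is a step that the two limits leave unreadable from compound 1 to compound 2, with methoxy in place of trifluoromethyl. It therefore gives no usable size for the next change.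

Compound 3 `Nc1nc(C(F)(F)F)cc2c1[nH]c(=O)n2Cc1ccc(NCC2CC2)nc1` has (cyclopropylmethyl)amino in place of methoxy on the same aromatic carbon, next to the ring nitrogen: (cyclopropylmethyl)amino in place of methoxy on an aromatic carbon. Going by the values given here, no measured compound carries an amino group at this place, so the data offer no direct precedent. A moderate upward step in this assay is nevertheless expected, though this expectation rests on the structural change alone and remains uncertain. The starting point is compound 2 at < 9 mL.min-1.g-1, which is a limit.

The estimated change is an at least 1.5-fold higher number from compound 2 to compound 3 (0.19 log units; that floor lies within the scatter). For compound 3 the expected value is 14 mL.min-1.g-1, with an estimated range from 7 mL.min-1.g-1 to 35 mL.min-1.g-1.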

Compound 3, intrinsic clearance in microsomes: 85 mL.min-1.g-1
Compound 3: the middle estimate sits 6.1-fold (0.78 log units) below what was measured; measured number above the stated range.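

For the compounds shown here, at this aromatic carbon, compound 1 and compound 2 gave no step that can be read in this assay, whereas compound 3 shows that the group placed here can matter: (cyclopropylmethyl)amino in place of methoxy gives an at least 9.4-fold higher number from compound 2 to compound 3 (0.97 log units; beyond the scatter), and (cyclopropylmethyl)amino in place of trifluoromethyl gives an at least 10-fold higher number from compound 1 to compound 3 (1.00 log units; beyond the scatter). Compound 2 stands only at a limit, which makes the first of these sizes a floor and leaves the full size of the step unknown: the limit of < 9 mL.min-1.g-1 in this assay, at which 1 of the 3 values shown sits. Compound 1 also stands only at a limit, and the second size is a floor for the same reason: the limit of < 8.5 mL.min-1.g-1 in this assay, at which 1 of the 3 values shown sits.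

The compounds shown leave open whether the rise follows the nitrogen of the entering group, its cyclopropylmethyl part, or the two together, since both change in the single step from methoxy. A plain amino group, a methylamino group and a cyclopropylmethoxy group on the same aromatic carbon would separate these parts, and the first two would also show how much of the step remains without the three-membered ring.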